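The source may report more compounds than this note shows. Statements on the series, on what has been measured and on what is new or still open speak of the compounds shown alone.

Among the compounds with values here, in an ADME assay on MT4 cells (Homo sapiens) for cytotoxicity, read by MTT assay (a higher number here means that more compound is tolerated, a lower number that less compound is tolerated), compound 1 `Cc1ccc(CC2C(=O)N(O)C(=O)c3ccccc32)cc1` gives 5500 nM and holds the lower of the two numbers measured so far. Compound 2 `O=c1c2ccccc2c(Cc2ccccc2)c(O)n1O` gives 88000 nM in this assay and lies higher, by a gap beyond the usual scatter.

The step followed here leads from compound 1 to compound 3 `O=C1c2ccccc2C(Cc2ccccc2)C(=O)N1O`. The change is hydrogen in place of methyl on an aromatic carbon and it puts hydrogen in place of methyl on an aromatic carbon, para to a large group, so that 4-methylphenyl becomes phenyl.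

Within the data shown here, no measured pair isolates this change, so the expectation rests on thin evidence. Compound 1 sits at the bottom of the small measured span, and compound 2 stands at 88000 nM at its top, so a rise is the more likely direction, of moderate size and probably beyond the scatter. A step within the scatter cannot be ruled out. The estimated move is a 4.5-fold higher number from compound 1 to compound 3 (0.66 log units; beyond the scatter) towards more compound tolerated. In this assay compound 3 is expected at 25000 nM within an estimated range from 6000 nM to 100000 nM.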

Compound 3, half-maximal cytotoxic concentration: 95000 nM
The estimate for compound 3 lay 3.8-fold (0.58 log units) below the measured number; measured number inside the range.
By their numbers in this assay, from the lowest: compound 1; then compounds 2 and 3 (each within the scatter of the next).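

In this assay, the loss of one methyl, which turns 4-methylphenyl into phenyl, brings a 17-fold higher number from compound 1 to compound 3 (1.24 log units; beyond the scatter), a large step towards more compound tolerated. This is the first pair among the compounds shown that differs in one place only, so the change can now be read directly rather than inferred from a gap between compounds that differ in more ways. It shows that this aromatic carbon, para to a large group, is not a silent position in this assay: on the core of compound 1, one carbon atom leaving and a hydrogen atom entering are enough to move the number well beyond the scatter, although no measurement shown bears on why the number moves.

On these data alone, the size of the step rests on this single pair, so it remains open whether a methyl at this position would bring a similar step on the core of compound 2. Also open, as far as these compounds go, is whether a methoxy group, a chlorine atom or an amine on the same aromatic carbon would give a number close to that of compound 1 or to that of compound 3 in this assay.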